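Adding a Chloro to the Trifluoromethylphenyl Urea

A few compounds are considered here, and "the series" means these few. Any claim that something is new, unique, unknown or untested is made for them only; others in the source may bear on it.

Compound 1 `O=C(Nc1cccc(-n2cc(-c3ccncc3)c(-c3ccc(Cl)c(O)c3)n2)c1)Nc1cccc(C(F)(F)F)c1` carries a (3-(trifluoromethyl)phenyl)amino group on its urea carbonyl and a hydroxy group on the chlorophenyl ring of the shared core. In a functional assay on IGROV-1 cells (Homo sapiens) for inhibition, read by sulforhodamine B assay, with a stated time of 48 h (a lower number here means that less compound is tolerated, a higher number that more compound is tolerated), compound 1 gives > 32500 nM, which is a limit of the assay and not a number. Compound 2 `COc1cc(-c2nn(-c3cccc(NC(=O)Nc4cccc(C(F)(F)F)c4)c3)cc2-c2ccncc2)ccc1Cl` has methyl in place of hydrogen on that oxygen, and in this assay compound 2 gives 50000 nM. Compound 3 `COc1cc(-c2nn(-c3cccc(NC(=O)c4ccc(Cl)c(C(F)(F)F)c4)c3)cc2-c2ccncc2)ccc1Cl` carries an amide in place of the urea. In this assay compound 3 gives > 32500 nM, again a limit and not a number. The step that the limit leaves unreadable from compound 1 to compound 2 and the step that the limit leaves unreadable from compound 2 to compound 3 are both unreadable because of the limit of > 32500 nM in this assay, at which 2 of the 3 values shown sit.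

Compound 4 `O=C(Nc1cccc(-n2cc(-c3ccncc3)c(-c3ccc(Cl)c(O)c3)n2)c1)Nc1ccc(Cl)c(C(F)(F)F)c1` is compound 1 with chloro in place of hydrogen on an aromatic carbon. Among the measured compounds shown here, no measured step exchanges only this hydrogen for chloro. Compound 3 does carry the 4-chloro-3-(trifluoromethyl)phenyl, but on an amide rather than a urea, and its value is a limit. With every value shown sitting at or near the limit, compound 4 is expected to do the same, so the expected step that the limit leaves unreadable from compound 1 to compound 4 is none beyond the scatter. Compound 4 is estimated at 40000 nM, between 15000 nM and 100000 nM.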

Compound 4, concentration lethal to 50% of the cells: > 32500 nM
Compound 4 ended at the assay's limit (the forecaster's own chance of this, stated with the estimate: 60%); the middle value is on the limit's open side.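

The step from compound 1 to compound 4 cannot be read, and no new comparison follows from compound 4, because both compounds end at a limit of the assay and not at a number: the limit of > 32500 nM in this assay, at which 3 of the 4 values shown sit.

The compounds shown leave open whether chloro in place of hydrogen on an aromatic carbon of this urea changes the result in this assay at all.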